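Fluoro for methyl on the sulfonyl ring of compound 3

A few compounds are considered here, and "the series" means these few. Any claim that something is new, unique, unknown or untested is made for them only; others in the source may bear on it.

compound 1 `O=C(/C=C/c1ccc(F)cc1)NS(=O)(=O)c1ccc(F)cc1`: 0.8 ug/mL
compound 2 `O=C(/C=C/c1ccc(Br)cc1)NS(=O)(=O)c1ccc(F)cc1`: 1.2 ug/mL
compound 3 `Cc1ccc(S(=O)(=O)NC(=O)/C=C/c2ccc(N(C)C)cc2)cc1`: 4.3 ug/mL

Of the compounds shown here, three have been measured in a functional assay on B16-F10 cells (Mus musculus) for antiproliferative activity, read by ELISA and MTT assay, with a stated time of 48 h; a lower number here means a stronger inhibitor, a higher number a weaker inhibitor. Within the data shown here, compound 1 gives 0.8 ug/mL, and compound 2 gives 1.2 ug/mL; the single measured step, a 1.5-fold higher number from compound 1 to compound 2 (0.18 log units; within the scatter), lies within the scatter. Compound 3, with 4.3 ug/mL, stands highest of the three numbers, beyond the scatter from both compound 2 and compound 1.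

Compound 4 `CN(C)c1ccc(/C=C/C(=O)NS(=O)(=O)c2ccc(F)cc2)cc1` is unmeasured. It differs from compound 3 by fluoro in place of methyl on an aromatic carbon. Among the measured compounds shown here, no measured step bears directly on this change: the one step in hand concerns bromo in place of fluoro on the other aromatic ring, and compounds 1 and 2, which carry the fluorophenyl sulfonyl group, also differ from compound 3 at the second ring, so their lower numbers cannot be attributed to the sulfonyl ring alone. A small step is therefore expected, with a slight lean toward a lower number for compound 4, estimated as a 1.4-fold lower number from compound 3 to compound 4 (0.16 log units; within the scatter). Compound 4 is expected to give 3 ug/mL in this assay, within the range 1.2 ug/mL to 8 ug/mL.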

Compound 4, half-maximal inhibitory concentration: 2.3 ug/mL
Beside the measured number, compound 4's estimate is 1.3-fold (0.12 log units) above it; the measured number falls inside the stated range.
By their numbers in this assay, from the lowest: compounds 1, 2, 4 and 3 (each within the scatter of the next, the first and the last beyond it).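

In this assay, the change from 4-methylphenyl to 4-fluorophenyl, with the dimethylamino group held in place, is a step within the scatter (a 1.9-fold lower number from compound 3 to compound 4 (0.27 log units; within the scatter)), so this exchange of methyl for fluoro cannot be told apart from no change. With the 4-fluorophenyl group held in place, the other aromatic ring can now be read: dimethylamino in place of bromo is also within the scatter (a 1.9-fold higher number from compound 2 to compound 4 (0.28 log units; within the scatter)), while dimethylamino in place of fluoro is a modest step beyond it (a 2.9-fold higher number from compound 1 to compound 4 (0.46 log units; beyond the scatter)). No measurement on hand accounts for these steps.

The compounds shown leave open whether methoxy or a carboxylic acid at the same place would shift the number beyond the scatter. They also leave open whether fluoro for methyl reads the same with bromo on the other aromatic ring.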